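Trimming the Amide Substituent Down to Methyl

A few compounds are considered here, and "the series" means these few. Any claim that something is new, unique, unknown or untested is made for them only; others in the source may bear on it.

Compound 1, `O=C(/C=C/c1ccc(NC(=O)Nc2ccc(Cl)c(C(F)(F)F)c2)cc1)NC1CCC1`: in a functional assay on KETR3 cells (Homo sapiens) for inhibition, read by MTT assay, with a stated time of 120 h (on this read-out higher numbers stand for weaker inhibition and lower numbers for stronger inhibition), compound 1 gives 17300 nM.
Compound 2, `CC(NC(=O)/C=C/c1ccc(NC(=O)Nc2ccc(Cl)c(C(F)(F)F)c2)cc1)c1ccccc1`: in this assay compound 2 gives 21200 nM.

Both measured compounds share one core and differ only in the group attached to the amide-type nitrogen. Compound 2 has the higher of the two numbers in this assay, and its nearest neighbour is compound 1; the step of a 1.2-fold higher number from compound 1 to compound 2 (0.09 log units; within the scatter) shows that replacing cyclobutyl with 1-phenylethyl on that nitrogen did not move the read-out beyond the usual scatter.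

Compound 3, `CNC(=O)/C=C/c1ccc(NC(=O)Nc2ccc(Cl)c(C(F)(F)F)c2)cc1`, continues along the same position: methyl in place of 1-phenylethyl on an amide-type nitrogen. Among the measured compounds shown here, the only step that bears on this change is a 1.2-fold higher number from compound 1 to compound 2 (0.09 log units; within the scatter), which was small, and it suggests that the amide substituent has little influence on the read-out in this assay across the compounds seen so far. With only two measured points, a shift in either direction cannot be ruled out, but none beyond the scatter is expected.

Compound 3 is therefore estimated at 18000 nM in this assay, within a range of 7000 nM to 45000 nM, which means an expected step of a 1.2-fold lower number from compound 2 to compound 3 (0.07 log units; within the scatter).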

Compound 3, half-maximal inhibitory concentration: 21200 nM
Compound 3: the middle estimate sits 1.2-fold (0.07 log units) below what was measured; the measured number falls inside the stated range.
By their numbers in this assay, from the lowest: compounds 1, 2 and 3 (each within the scatter of the next).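

Cutting the group on the amide-type nitrogen from 1-phenylethyl, with 8 heavy atoms and an aromatic ring, to methyl, with 1 heavy atom and no ring, gives no change at the digits printed from compound 2 to compound 3 (within the scatter) in this assay, so the aromatic ring and nearly all of the group's bulk can go without a visible effect on this read-out. Methyl in place of cyclobutyl gives a 1.2-fold higher number from compound 1 to compound 3 (0.09 log units; within the scatter), which means that the three groups now seen at this position, from the smallest to the largest, all lie within the scatter of one another, and the flat picture suggested by the first pair now holds across a much wider range of group size. Nothing available here explains why this position makes so little difference to the read-out.

Going by these compounds, all three groups are built from carbon alone, so it remains open whether an amine, a carboxylic acid or a longer chain carrying a hydroxyl group on this nitrogen would behave the same way. On these data alone, it is also open whether a plain amide, with hydrogen in place of methyl, would stay within the scatter of these three compounds.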